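A few compounds are considered here, and "the series" means these few. Any claim that something is new, unique, unknown or untested is made for them only; others in the source may bear on it.

Compound 3 `O=c1[nH]cc(S(=O)(=O)Nc2ccc(-c3cn(-c4cccc(F)c4)nn3)cc2)c(=O)[nH]1` gives in a functional assay on HepG2 cells (Homo sapiens) for antiproliferative activity, read by MTT assay, with a stated time of 24 h (on this read-out higher numbers stand for weaker inhibition and lower numbers for stronger inhibition), only a limit, > 20000 nM. Compound 2 `O=c1[nH]cc(S(=O)(=O)Nc2ccc(-c3cn(-c4ccccc4F)nn3)cc2)c(=O)[nH]1` also reaches only a limit in this assay, > 20000 nM. Compound 1 `Cc1ccccc1-n1cc(-c2ccc(NS(=O)(=O)c3c[nH]c(=O)[nH]c3=O)cc2)nn1` gives 14500 nM in this assay. The measured step from compound 1 to compound 3 was an at least 1.3-fold higher number from compound 1 to compound 3 (0.13 log units; that floor lies within the scatter), and the step from compound 2 to compound 3 was a step that the two limits leave unreadable from compound 2 to compound 3. Worth noting is the limit of > 20000 nM in this assay, at which 2 of the 3 values shown sit. Compound 4 `O=c1[nH]cc(S(=O)(=O)Nc2ccc(-c3cn(-c4ccc(F)cc4)nn3)cc2)c(=O)[nH]1` differs from compound 3 by 4-fluorophenyl in place of 3-fluorophenyl on an aromatic nitrogen. The nearest comparison, moving fluorine around the same ring, is the step from compound 2 to compound 3, which gave no readable size, so no step beyond the scatter is expected here. Compound 4 is therefore expected near 25000 nM, within 8000 nM to 80000 nM. That estimate means an expected step that the limit leaves unreadable from compound 3 to compound 4.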

Compound 4, half-maximal inhibitory concentration: > 20000 nM
Compound 4 was reported as a limit (the forecaster's own chance of this, stated with the estimate: 70%); the middle value does not contradict the limit.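

With 4-fluorophenyl on this aromatic nitrogen, all three fluorophenyl compounds now stop at the same limit of the assay: the limit of > 20000 nM in this assay, at which 3 of the 4 values shown sit. The steps among compound 2, compound 3 and compound 4 cannot be read, so moving the fluorine around this ring shows no readable effect. Going by these compounds alone, the one step that can be read is an at least 1.3-fold higher number from compound 1 to compound 4 (0.13 log units; that floor lies within the scatter).

From the compounds shown here alone, how the three fluorophenyl compounds truly rank stays open. Also open, going by these compounds, is whether an amine or a longer chain on this phenyl ring would give a measurable number.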